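The compounds below may be only part of what the source reports. "The series", "measured", "known", "first", "only" and "open" are said of these compounds alone.

Compound 1 `Cc1ccc(-c2nc3ccccc3s2)cc1NC(=O)c1cc([N+](=O)[O-])c(N2CCCCC2)cc1Cl`: > 25000 nM
Compound 2 `O=C(Nc1ccc(O)c(-c2nc3ccccc3s2)c1)c1cc([N+](=O)[O-])ccc1Cl`: > 25000 nM
Compound 3 `O=C(O)COc1cc(Cl)c(C(=O)Nc2cccc(-c3nc4ccccc4s3)c2)cc1[N+](=O)[O-]`: > 25000 nM

All three were tested in an ADME assay on HEK293 cells (Homo sapiens) for cytotoxicity, with a stated time of 72 h; on this read-out lower numbers stand for an effect already at smaller amounts and higher numbers for an effect only at larger amounts of compound. For compound 1 the result > 25000 nM is a limit of the assay, not a number. Compound 2 likewise reached only a limit. Compound 3 also reached only a limit. Going by the values given here, every value shown therefore sits at the limit of > 25000 nM in this assay, at which 3 of the 3 values shown sit, so no measured step exists between these compounds.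

Compound 4 `COC(=O)C1CCN(c2cc(Cl)c(C(=O)Nc3cc(-c4nc5ccccc5s4)ccc3C)cc2[N+](=O)[O-])CC1` has not yet been measured. It differs from compound 1 in one place: methoxycarbonyl in place of hydrogen on a saturated ring carbon. Among the compounds with values here, no measured pair shows what this change does. Within the data shown here, since the only evidence is the limit of > 25000 nM in this assay, at which 3 of the 3 values shown sit, the step is expected to be none beyond the scatter, namely a step that the limit leaves unreadable from compound 1 to compound 4. Compound 4 is thus expected to give about 30000 nM, within 12000 nM to 100000 nM, most likely again only a limit.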

Compound 4, half-maximal effective concentration: > 25000 nM
Compound 4: a limit, no number; the forecaster's own chance of this, stated with the estimate: 85%; the middle value lies beyond the limit too.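

Compound 4, like compound 1, reaches only a limit in this assay, so no step can be read between them: the limit of > 25000 nM in this assay, at which 4 of the 4 values shown sit. The compounds shown leave open at what concentration, if any, they would harm these cells.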